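The compounds below may be only part of what the source reports. "The series", "measured", "known", "first", "only" and "open" are said of these compounds alone.

Measured in a functional assay on the whole organism for agonist activity, with Mus musculus as the target; a higher number here means that more compound is needed for the effect, a lower number that less compound is needed:
Compound 1, `CC(=O)N(C)C(C)C#CCn1ccnc1`: 3 mg/kg.
Compound 2, `CC(=O)N(C)C(C)C#CCn1cncc1C`: > 100 mg/kg, which is a limit of the assay and not a number.
Compound 3, `COC(=O)N(C)CC#CCn1ccnc1`: 4.5 mg/kg.

Compound 2 differs from compound 1 by methyl in place of hydrogen on an aromatic carbon. The step of an at least 33-fold higher number from compound 1 to compound 2 (1.52 log units; beyond the scatter) is set by the limit of > 100 mg/kg in this assay, at which 1 of the 3 values shown sits, so only its lower bound is known. Compound 3 stands within the scatter of compound 1; how the two cores differ is not broken down here.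

Compound 4, `COC(=O)N(C)CC#CCn1cncc1C`, has not been measured. It differs from compound 3 by methyl in place of hydrogen on an aromatic carbon, the same change as that from compound 1 to compound 2, made on the core of compound 3. A step of comparable size, a 33-fold higher number from compound 3 to compound 4 (1.52 log units; beyond the scatter), is expected, resting on the measured step of an at least 33-fold higher number from compound 1 to compound 2 (1.52 log units; beyond the scatter) from compound 1. Compound 4 is therefore estimated at 150 mg/kg in this assay, with a good chance that only a limit is reported.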

Compound 4, dose for half-maximal effect: > 100 mg/kg
Compound 4: a limit, no number; the forecaster's own chance of this, stated with the estimate: 70%; the middle value does not contradict the limit.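

The change of methyl in place of hydrogen on an aromatic carbon carries over to the core of compound 3: in this assay the step is an at least 22-fold higher number from compound 3 to compound 4 (1.34 log units; beyond the scatter), in the same direction as on the core of compound 1. Compound 4 gives > 100 mg/kg, which is a limit of the assay and not a number. The change is therefore shown to carry over in direction, but not in size: the same change on two cores in this assay, an at least 33-fold higher number (1.52 log units; beyond the scatter) from compound 1 to compound 2 and an at least 22-fold higher number (1.34 log units; beyond the scatter) from compound 3 to compound 4; the limit leaves it open whether they differ

As far as these compounds go, it remains open whether ethyl or chlorine in place of the same hydrogen would also raise the number this far. From the compounds shown here alone, it also remains open what methyl would do on another aromatic carbon of the ring.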